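Sulfur substituent swap in the compound 1 series

The compounds below may be only part of what the source reports. "The series", "measured", "known", "first", "only" and "open" are said of these compounds alone.

In a functional assay on DU-145 cells (Homo sapiens) for inhibition, read by trypan blue exclusion, with a stated time of 96 h (a higher number here means a weaker inhibitor of growth, a lower number a stronger inhibitor of growth), compound 1 `O=C(/C(=C\c1c[nH]c2ccc(Br)cc12)SCc1ccc(F)cc1)c1ccc(Cl)cc1` gives 50000 nM. Compound 2 `COc1ccccc1/C=C(/SCc1ccc(F)cc1)C(=O)c1ccc(Cl)cc1` gives 10000 nM, and compound 3 `CN(C)c1ccc(/C=C(/SCc2ccc(F)cc2)C(=O)c2ccc(Cl)cc2)cc1` gives 50000 nM. Among the compounds with values here, compound 1 stands level with compound 3 at the digits given, the two together the highest of the three numbers; its only step beyond the scatter is a 5.0-fold lower number from compound 1 to compound 2 (0.70 log units; beyond the scatter), while no change at the digits printed from compound 1 to compound 3 (within the scatter) and a 5.0-fold higher number from compound 2 to compound 3 (0.70 log units; beyond the scatter) complete the set. Compound 4 `Cc1ccc(S/C(=C/c2c[nH]c3ccc(Br)cc23)C(=O)c2ccc(Cl)cc2)cc1` differs from compound 1 in one place: 4-methylphenyl in place of 4-fluorobenzyl on a sulfur. Within the data shown here, none of the measured steps touches the sulfur; each of them changes the group on the double-bonded chain carbon, so no step bears directly on this change. Compound 1 already sits at the weak end of the three numbers, and the measured steps moved the number at most modestly. Compound 4 is therefore expected to stay close to compound 1, with a 1.3-fold lower number from compound 1 to compound 4 (0.10 log units; within the scatter) not beyond the scatter. The estimate for compound 4 is 40000 nM, within 12000 nM to 100000 nM.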

Compound 4, concentration for 50% growth inhibition: 1000 nM
Beside the measured number, compound 4's estimate is 40-fold (1.60 log units) above it, outside the stated range (below it).
By their numbers in this assay, from the lowest: compound 4; then compound 2; then compounds 1 and 3 (each within the scatter of the next).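

In this assay, the group on the sulfur proves to be a far more sensitive point than the double-bonded chain carbon: 4-methylphenyl in place of 4-fluorobenzyl gives a 50-fold lower number from compound 1 to compound 4 (1.70 log units; beyond the scatter), whereas the largest earlier step is a 5.0-fold lower number from compound 1 to compound 2 (0.70 log units; beyond the scatter). This is the only large step in the series so far, and it comes from the first change shown at the sulfur. Nothing on hand explains the size of this step.

The change alters both the link to the ring and the group on the ring, so 4-fluorophenyl or 4-methylbenzyl on the sulfur would be needed to separate the two. On these data alone, it also remains open whether the same swap holds with the 2-methoxyphenyl group of compound 2 in place of 5-bromo-1H-indol-3-yl.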